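Adding one methyl to the 2-aminobutoxy chain

The compounds below may be only part of what the source reports. "The series", "measured", "known", "first", "only" and "open" are said of these compounds alone.

Measured in a functional assay on MCF7 cells (Homo sapiens) for inhibition, read by fluorescence, with a stated time of 72 h; a higher number here means a weaker inhibitor, a lower number a stronger inhibitor:
compound 1 `CC(C)n1cnc2c(NC(=N)N)nc(NCCCO)nc21` 8800 nM
compound 2 `CC(C)n1cnc2c(NC(=N)N)nc(NCCCCCCO)nc21` 5200 nM
compound 3 `CC[C@H](N)COc1nc(NC(=N)N)c2ncn(C(C)C)c2n1` 16300 nM

Swapping the whole side chain gives a 1.9-fold higher number from compound 1 to compound 3 (0.27 log units; within the scatter) and a 3.1-fold higher number from compound 2 to compound 3 (0.50 log units; beyond the scatter). The number for compound 3 is therefore clearly separated from compound 2 alone. Compound 4 `CC(C)[C@H](N)COc1nc(NC(=N)N)c2ncn(C(C)C)c2n1` makes one small change to compound 3: methyl in place of hydrogen on a saturated chain carbon bound to two saturated chain carbons. This turns 2-aminobutyl to 2-amino-3-methylbutyl. Among the measured compounds shown here, no measured step makes this exact change. The nearest guide is a longer chain, which gave a 1.7-fold lower number from compound 1 to compound 2 (0.23 log units; within the scatter), so no step beyond the scatter is expected in this assay. The expected step is a 1.1-fold lower number from compound 3 to compound 4 (0.04 log units; within the scatter). Compound 4 is estimated at 15000 nM, with an expected range of 6000 nM to 38000 nM.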

Compound 4, half-maximal inhibitory concentration: 3400 nM
Estimate against measurement, compound 4: 4.4-fold (0.64 log units) above; measured number below the stated range.
By their numbers in this assay, from the lowest: compounds 4, 2, 1 and 3 (each within the scatter of the next, the first and the last beyond it).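

A single added methyl, turning ethyl to isopropyl on the saturated chain carbon, gives a 4.8-fold lower number from compound 3 to compound 4 (0.68 log units; beyond the scatter) in this assay, so one carbon at this position is enough to move the number beyond the scatter. It also closes the separation from the aminohexanol-type chain, with a 1.5-fold lower number from compound 2 to compound 4 (0.18 log units; within the scatter) inside the scatter, while a 2.6-fold lower number from compound 1 to compound 4 (0.41 log units; beyond the scatter) stays beyond it. No evidence here explains the step. Going by these compounds, what a tert-butyl or a phenyl group would do in place of the isopropyl end of the chain stays open.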